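The source may report more compounds than this note shows. Statements on the series, on what has been measured and on what is new or still open speak of the compounds shown alone.

Measured compounds:

Compound 1, `O=S(=O)(NCCCNCc1ccc(Cl)cc1)c1cc(C(F)(F)F)cc(C(F)(F)F)c1`, in a functional assay on MIA PaCa-2 cells (Homo sapiens) for inhibition, read by MTT assay, with a stated time of 72 h (a lower number here means a stronger inhibitor of growth, a higher number a weaker inhibitor of growth), compound 1 gives 2800 nM.
Compound 2, `CC(C)c1ccc(S(=O)(=O)NCCCCCCNCc2ccc(Br)cc2)cc1`, in this assay compound 2 gives 5730 nM.

Of the two numbers shown, compound 2 stands highest, and compound 1 gives the lower number, a gap that lies beyond the usual scatter of this kind of measurement. Among the compounds with values here, no step between two measured compounds differing in a single place has been characterised, so nothing about the effect of any one change is known from these two alone.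

Compound 3, `Cc1ccc(S(=O)(=O)NCCCCCCNCc2ccc(Br)cc2)cc1`, has not yet been measured. It differs from compound 2 in one place: methyl in place of isopropyl on an aromatic carbon. Isopropyl leaves and methyl enters, on an aromatic carbon of the six-membered aromatic ring of carbon only, para to a large group; the rest of the molecule is unchanged.

Within the data shown here, with no comparable step available, the change from compound 2 to compound 3 is expected to be small, likely within or only slightly beyond the scatter, with a modest lean toward a higher number, as a 1.3-fold higher number from compound 2 to compound 3 (0.12 log units; within the scatter). Compound 3 is therefore estimated at 7500 nM, with a range from 3000 nM to 19000 nM.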

Compound 3, concentration for 50% growth inhibition: 12300 nM
For compound 3 the middle estimate is 1.6-fold (0.21 log units) below the measured one; the measured number falls inside the stated range.
By their numbers in this assay, from the lowest: compound 1; then compound 2; then compound 3.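

In this assay, within the data shown here, exchanging isopropyl for methyl on an aromatic carbon, para to a large group, gives a 2.1-fold higher number from compound 2 to compound 3 (0.33 log units; beyond the scatter), the first single change that can be read. It shows that the group at this position matters to growth inhibition: the step lies beyond the scatter, though it is modest, and the methyl of one heavy atom gives the weaker result of the two, against the isopropyl of three heavy atoms. No measurement offered here bears on the reason for this difference.

From the compounds shown here alone, with only these two groups compared, it remains open how a hydrogen, a tert-butyl group or a methoxy group at this position would read, and so whether the number follows the size of the group at all. Compound 1 differs from the other two compounds in more than one place, so what its chain, its trifluoromethyl groups and its chlorine each contribute stays unresolved, as does whether the exchange of isopropyl for methyl would give a similar step elsewhere in the series.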